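A few compounds are considered here, and "the series" means these few. Any claim that something is new, unique, unknown or untested is made for them only; others in the source may bear on it.

Measured so far in a functional assay on the whole organism (strain Albino) for inhibition, with Rattus norvegicus as the target, with stated times of 1 h and 2 h, at a dose of 20 mg/kg by the oral route; a higher number here means more inhibition at the dose given (going by the name of the read-out), a lower number less inhibition:
compound 1 `COc1cc(C2NC(=S)NC(c3ccc(C)cc3)=C2CCC(=O)O)cc(OC)c1OC`: 14.2%
compound 2 `O=C(O)CCC1=C(c2ccccc2)NC(=S)NC1c1ccccc1O`: 28.6%
compound 3 `COc1ccc(C2=C(CCC(=O)O)C(c3ccccc3O)NC(=S)N2)cc1`: 27%

Compound 2 stands highest of the three numbers in this assay; compound 3 lies within the scatter of it, while compound 1 lies beyond the scatter below it. For the measured compounds named here, the only step between compounds differing in a single place is a number 1.6 percentage points lower from compound 2 to compound 3 (within the scatter), a methoxy in place of hydrogen on an aromatic carbon, and it falls within the scatter.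

Compound 4 `O=C(O)CCC1=C(c2ccccc2)NC(=S)NC1c1ccco1` has not yet been measured in this assay. It differs from compound 2 as follows: furan-2-yl in place of 2-hydroxyphenyl on a saturated ring carbon. Going by the values given here, no measured step exchanges the group on the saturated ring carbon, so none bears directly on this change. Among the compounds with values here, compound 1 and compound 2 differ in several places at once, so their gap shows only that the numbers of this set run from where compound 1 gives 14.2% to where compound 2 gives 28.6%. With nothing to anchor the change, the step of a number 8.6 percentage points lower from compound 2 to compound 4 (within the scatter) is expected to be modest and directed toward the lower part of that range. Compound 4 is therefore estimated at 20%, with a range from 6% to 34%.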

Compound 4, a percentage reported as inhibition, in the whole organism at one dose (the size of the read-out at that dose, not a potency): 21.8%
Compound 4: the middle estimate sits 1.8 percentage points below what was measured; measured number inside the range.
By their numbers in this assay, from the lowest: compounds 1, 4, 3 and 2 (each within the scatter of the next, the first and the last beyond it).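

In this assay, for the compounds shown here, the exchange of 2-hydroxyphenyl for furan-2-yl on the saturated ring carbon gives a number 6.8 percentage points lower from compound 2 to compound 4 (within the scatter), the first step that can be read at this position. Within this single pair, the 2-hydroxyphenyl group, with its hydrogen-bond donor, is therefore not needed for a reading within the scatter of compound 2, since furan-2-yl carries no such donor and has fewer heavy atoms. No available evidence explains this result.

The compounds shown leave open whether an unsubstituted phenyl or a cyclohexyl on this carbon would also stay within the scatter of compound 2. They also leave open whether furan-2-yl would give a similar step alongside the methoxy-bearing aromatic group of compound 3.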